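Removing a Methyl Group from a Weakly Cytotoxic Compound

The compounds below may be only part of what the source reports. "The series", "measured", "known", "first", "only" and "open" are said of these compounds alone.

So far two compounds have been measured in a functional assay on HeLa cells (Homo sapiens) for cytotoxicity, read by MTT assay, with a stated time of 48 h; on this read-out higher numbers stand for weaker inhibition and lower numbers for stronger inhibition. Compound 1, with structure `O=Cc1c(O)ccc2oc(-c3ccco3)nc12`, gives > 30000 nM, which is a limit of the assay rather than a number. Compound 2, with structure `CC(=O)c1c(O)ccc2oc(-c3ccccc3C)nc12`, gives 19200 nM in this assay. Among the compounds with values here, compound 2 therefore holds the only number found so far. The other value shown, for compound 1, sits at the limit of > 30000 nM in this assay, at which 1 of the 2 values shown sits. Within the data shown here, with one number and one limit, no step between measured compounds can be drawn.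

Compound 3, with structure `CC(=O)c1c(O)ccc2oc(-c3ccccc3)nc12`, has not yet been measured in this assay. It differs from compound 2 by hydrogen in place of methyl on an aromatic carbon. Among the measured compounds shown here, none of the measured compounds shows what such a change does here. The expected step in this assay is a 1.0-fold higher number from compound 2 to compound 3 (0.02 log units; within the scatter), small and with no direction beyond the usual scatter. Compound 3 is thus estimated at 20000 nM in this assay, with a range from 8000 nM to 50000 nM, and a fair chance that only a limit is reported.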

Compound 3, half-maximal inhibitory concentration: > 30000 nM
Compound 3 ended at the assay's limit (the forecaster's own chance of this, stated with the estimate: 30%); middle value at least 1.5-fold (0.17 log units) from the limit.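

In this assay hydrogen in place of methyl, on an aromatic carbon ortho to a large group, now has its first measured step, which is an at least 1.5-fold higher number from compound 2 to compound 3 (0.19 log units; that floor lies within the scatter) and sets only a floor on the size of the change. The true step could lie within the scatter or be far larger, so this result does not show whether the methyl group matters for the cytotoxicity of compound 2. Within the data shown here, it does show that this change does not bring a lower number, and it leaves compound 2 as the only compound with a measured number, while the other compounds stop at the end of the measurable range: the limit of > 30000 nM in this assay, at which 2 of the 3 values shown sit.

On these data alone, whether any other group on this aromatic carbon would give a lower number remains open, and a methoxy group, a chlorine atom, an amine or a carboxylic acid could each behave differently from methyl. Also open, as far as these compounds go, is the true size of the step, which cannot be read until compound 3 has a number rather than a limit.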